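Removing the bromo group from compound 2

The source may hold more compounds than are shown below. What is called first, only, known or untested is meant among the compounds shown, and "the series" means these compounds.

Measured in a functional assay on NZB5 cells (Homo sapiens) for inhibition, read by thymidine incorporation, with a stated time of 5 days; on this read-out lower numbers stand for stronger inhibition and higher numbers for weaker inhibition:
- compound 1 `Cc1ccc(N)cc1S(=O)(=O)N(C)/N=C/c1cnn2ccc(C#N)cc12` ("not determined" (no result reported))
- compound 2 `Cc1ccc(Br)cc1S(=O)(=O)N(C)/N=C/c1cnn2ccc(C#N)cc12` (700 nM)
- compound 3 `CC(C)c1ccc([N+](=O)[O-])cc1S(=O)(=O)N(C)/N=C/c1cnn2ccc(C#N)cc12` (180 nM)

Compound 2 (700 nM) has the higher of the two numbers available. Compound 3 (180 nM) lies lower, beyond the usual scatter, and compound 1 offers no number for comparison.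

The next compound to be tested is compound 4 `Cc1ccccc1S(=O)(=O)N(C)/N=C/c1cnn2ccc(C#N)cc12`, with hydrogen in place of bromo on an aromatic carbon. Going by the values given here, no measured pair isolates this change, so the expectation is tentative. A small step toward weaker inhibition in this assay is expected, not clearly beyond the scatter. The estimated step runs (a 1.7-fold higher number from compound 2 to compound 4 (0.23 log units; within the scatter)). For compound 4 the expected value is 1200 nM (estimated range 350 nM to 4000 nM).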

Compound 4, half-maximal inhibitory concentration: > 20000 nM
Compound 4 was reported as a limit; the forecaster's own chance of this, stated with the estimate: 10%; middle value at least 16-fold (1.22 log units) away from the limit.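

In this assay, this aromatic carbon, para to a methyl group, proves far from indifferent: hydrogen in place of bromo gives an at least 28-fold higher number from compound 2 to compound 4 (1.45 log units; beyond the scatter). Going by these compounds alone, this is the first single-place comparison, and it ties much of the inhibition seen with compound 2 to the bromo group. Compound 4 is reported only as a limit, so the step gives a minimum size and not an exact one: the limit of > 20000 nM in this assay, at which 1 of the 4 values shown sits.

Going by these compounds, what a chloro group, a methoxy group or a carboxylic acid would give on this carbon remains open. Compound 1, with an amine there, provides no number for comparison.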